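Swapping the pyridine substituent on a thiosemicarbazone amidine

This account rests on a few compounds, and the source may have more. Where it says the series, first, only, none or still open, it means among the compounds named here.

Of the compounds shown here, three of one family have been measured in a functional assay on A-431 cells (Homo sapiens) for cytotoxicity, read by MTT assay, with a stated time of 72 h, tested at 10 uM; on this read-out lower numbers stand for less inhibition of growth and higher numbers for more inhibition of growth at the one concentration tested. Compound 1 `Cc1ccnc(/C(N)=N/NC(=S)N2CCCC2)c1` gives 71.2% in this assay. Compound 3 `Cc1ccnc(/C(N)=N/NC(=S)N2CCOCC2)c1` gives 62%. Compound 2 `N/C(=N\NC(=S)N1CCN(c2ccccn2)CC1)c1ccc(F)cn1` gives 47.4%, the lowest of the three numbers; its nearest neighbour is compound 3, and its largest gap is to compound 1, both gaps beyond the scatter. Within the data shown here, the one measured step between neighbours, a number 9.2 percentage points lower from compound 1 to compound 3 (within the scatter), lies within the scatter, so exchanging the group on the thiocarbonyl carbon made no clear difference.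

Compound 4 `Cc1ccnc(/C(N)=N/NC(=S)N2CCN(c3ccccn3)CC2)c1` has not yet been measured. It differs from compound 2 in one place: 4-methylpyridin-2-yl in place of 5-fluoropyridin-2-yl on a carbon with a double bond to nitrogen. Among the measured compounds shown here, no measured pair shows this exchange on its own, because compound 2 also carries a different group on the thiocarbonyl carbon than compound 1 and compound 3. For the measured compounds named here, the only guidance is that both compounds with the 4-methylpyridin-2-yl group, compound 1 and compound 3, sit higher in this assay than compound 2, while the thiocarbonyl change itself stayed within the scatter. An upward step a number 12.6 percentage points higher from compound 2 to compound 4 (beyond the scatter) is therefore expected, though with wide uncertainty. Compound 4 is estimated at 60%, with a plausible range from 42% to 76%.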

Compound 4, percent growth inhibition at one concentration: 44%
Beside the measured number, compound 4's estimate is 16 percentage points above it; the measured number falls inside the stated range.
By their numbers in this assay, from the lowest: compounds 4 and 2 (each within the scatter of the next); then compounds 3 and 1 (each within the scatter of the next).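

Among these compounds, the step of a number 3.4 percentage points lower from compound 2 to compound 4 (within the scatter) in this assay is the first reading of this exchange on its own, with the group on the thiocarbonyl carbon held the same, and it shows that 4-methylpyridin-2-yl and 5-fluoropyridin-2-yl make no clear difference in this pair. The 4-methylpyridin-2-yl group therefore does not by itself go with the higher numbers: compound 4 gives 44% against 62% for compound 3 and 71.2% for compound 1, three compounds that carry this group and differ only in the group on the thiocarbonyl carbon. No measurement at hand explains why the two pyridine groups read alike or why these values lie apart.

The compounds shown leave open whether the exchange would also make no clear difference with pyrrolidin-1-yl or morpholin-4-yl on the thiocarbonyl carbon, where the numbers for the 4-methylpyridin-2-yl compounds are higher. They also leave open how a quite different group on the carbon with a double bond to nitrogen, such as a plain phenyl ring or a pyridine ring carrying a carboxylic acid, would read.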